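Cyclobutyl for Cyclopropyl on the Piperazine Amide

The source may report more compounds than this note shows. Statements on the series, on what has been measured and on what is new or still open speak of the compounds shown alone.

Measured compounds:
compound 1, `Cc1nc(N2CCC(C(=O)NC(C)C)CC2)nc2ccc(NC(=O)COc3ccc(Cl)cc3)cc12`, 70%
compound 2, `Cc1nc(N2CCN(C(=O)C3CC3)CC2)nc2ccc(NC(=O)COc3ccc(OC(F)(F)F)cc3)cc12`, 59%

In an ADME assay on microsomes from liver (Homo sapiens) for metabolic stability, read by HPLC, with a stated time of 30 min, tested at 10 uM (a lower number here means that less of the compound is left, a higher number that more of the compound is left), compound 1 gives 70%, while compound 2 gives 59%. Compound 2 thus stands at the lower of the two numbers, and its gap to compound 1 lies beyond the usual scatter of this assay. Compound 3 `Cc1nc(N2CCN(C(=O)C3CCC3)CC2)nc2ccc(NC(=O)COc3ccc(OC(F)(F)F)cc3)cc12` has not yet been measured. It differs from compound 2 in one place only: cyclobutyl in place of cyclopropyl on a carbonyl carbon, the whole group reading 4-(cyclobutylcarbonyl)piperazin-1-yl instead of 4-(cyclopropylcarbonyl)piperazin-1-yl. Going by the values given here, no measured pair in this set shows that change, so nothing is known here about its size. The step is expected to be a small decrease, a number 7 percentage points lower from compound 2 to compound 3 (within the scatter), about at the edge of the scatter. Compound 3 is therefore estimated at 52%, within a range from 35% to 70%.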

Compound 3, percent of the compound remaining in the Homo sapiens assay: 52%
Estimate against measurement, compound 3: no gap at the digits printed; the measured number falls inside the stated range.
By their numbers in the Homo sapiens assay, from the lowest: compounds 3 and 2 (each within the scatter of the next); then compound 1.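

Going by these compounds alone, on a carbonyl carbon whose other neighbour is an amide-type nitrogen in a ring, cyclobutyl in place of cyclopropyl gives in the Homo sapiens assay a step of a number 7 percentage points lower from compound 2 to compound 3 (within the scatter), with compound 2 at 59% and compound 3 at 52%, and so provides the first reading of this change, which the earlier pair, differing in more than one place, could not give. In a physicochemical assay for solubility, in phosphate buffer (a higher number here means a more soluble compound, a lower number a less soluble compound), the same change gives a 2.0-fold lower number from compound 2 to compound 3 (0.30 log units; within the scatter), with compound 2 at 8000 nM and compound 3 at 4000 nM, and thus, at this position, neither read-out separates the cyclobutyl amide from the cyclopropyl amide. The data shown offer no measured reason for either step.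

On these data alone, whether cyclopentyl, tert-butyl or an oxetane ring on this carbonyl would stand apart from cyclopropyl in either read-out remains open. Compound 1 differs from compound 2 in more than one place, so its gap to that compound cannot be assigned to any single group.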